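From hydroxy to methoxymethoxy on compound 3

The compounds below may be only part of what the source reports. "The series", "measured", "known", "first", "only" and "open" are said of these compounds alone.

Among the measured compounds shown here, compound 3 `CCCCC/C=C\C/C=C\CCCCCCCc1cc(=O)c2c(O)cc(O)cc2o1` gives 17500 nM in a functional assay on MCF7 cells (Homo sapiens) for antiproliferative activity, read by MTT assay (a lower number here means a stronger inhibitor, a higher number a weaker inhibitor), and holds the only number. Compound 1 `CCCC/C=C\CCCCCCCCCc1cc(=O)c2c(O)cc(OCOC)cc2o1` reads > 67200 nM which is a limit of the assay. Compound 2 `CCCCC/C=C\C/C=C\CCCCCCCc1cc(=O)c2c(O)c(C)c(OCOC)cc2o1` reads > 67200 nM which is also a limit. Compound 4 `CCCCC/C=C\C/C=C\CCCCCCCc1cc(=O)c2c(O)cc(OCOC)cc2o1` puts methoxymethyl in place of hydrogen on an oxygen on an aromatic ring of compound 3, hydroxy to methoxymethoxy, with methoxymethyl in place of hydrogen on an oxygen on an aromatic ring as the counted difference. The estimated step of a 3.8-fold higher number from compound 3 to compound 4 (0.58 log units; beyond the scatter) is expected towards weaker inhibition and beyond the scatter. Compound 1 and compound 2 both carry methoxymethoxy, and this expectation rests on the limit of > 67200 nM in this assay, at which 2 of the 3 values shown sit, for those two. Compound 4 is estimated at 67000 nM within 30000 nM to 120000 nM and is expected quite possibly to end up only as a limit.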

Compound 4, half-maximal inhibitory concentration: > 67200 nM
Compound 4 was reported as a limit (the forecaster's own chance of this, stated with the estimate: 65%); middle value at least 1.0-fold (0.00 log units) from the limit.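

In this assay, among the compounds shown here, this is the first pair differing only at this oxygen, and methoxymethyl in place of hydrogen gives an at least 3.8-fold higher number from compound 3 to compound 4 (0.58 log units; beyond the scatter); the value of compound 4 is a limit, so this step gives only a lower bound. Compound 3 alone gives a number, and all three compounds carrying methoxymethoxy share one limit: the limit of > 67200 nM in this assay, at which 3 of the 4 values shown sit.

The steps from compound 2 and compound 1 to compound 4 cannot be read, so the methyl and chain changes remain unresolved. Also open, on these data alone, is whether a smaller methoxy group or an amine at this oxygen would retain measurable activity.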